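The source may hold more compounds than are shown below. What is called first, only, known or untested is meant among the compounds shown, and "the series" means these compounds.

Measured compounds:
- compound 1, `COc1c(N2CC[C@@H](N)C2)c(F)cc2c(=O)c(C(=O)O)cn(Cc3ccc(-c4ccccc4)cc3)c12`: 92200 nM
- compound 2, `O=C(O)c1cn(Cc2ccc(-n3cccn3)cc2)c2cc(NC[C@H]3CCNC3)c(F)cc2c1=O`: 187000 nM

In an assay on isolated protein for inhibition of DNA topoisomerase 1 (Homo sapiens), with a stated time of 15 min (on this read-out lower numbers stand for stronger inhibition and higher numbers for weaker inhibition), compound 1 gives 92200 nM, and compound 2 gives 187000 nM. Of these two numbers, compound 1 holds the lower one, and the gap between the two lies beyond the usual scatter of repeated measurements, so compound 1 stands as the stronger inhibitor of the pair.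

Compound 3, `COc1c(N2CC[C@@H](C(N)=O)C2)c(F)cc2c(=O)c(C(=O)O)cn(Cc3ccc(-c4ccccc4)cc3)c12`, is not yet measured. It differs from compound 1 in one place: carbamoyl in place of amino on a saturated ring carbon. Cut one bond further out, the change reads 3-aminopyrrolidin-1-yl to 3-carbamoylpyrrolidin-1-yl.

Within the data shown here, no measured pair shows the effect of this change, so the step from compound 1 to compound 3 in this assay has to be guessed from compound 1 alone. Because compound 1 already gives 92200 nM, a weak inhibition, the expectation is a small step, if any, likely toward a somewhat higher number: a 1.4-fold higher number from compound 1 to compound 3 (0.15 log units; within the scatter). Compound 3 is therefore estimated at 130000 nM, with a plausible range from 40000 nM to 400000 nM.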

Compound 3, half-maximal inhibitory concentration: > 200000 nM
Compound 3 gave a limit, no number; the forecaster's own chance of this, stated with the estimate: 15%; middle value at least 1.5-fold (0.18 log units) away from the limit.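

In this assay, compound 3 gives > 200000 nM, which is a limit of the assay and not a number. Putting carbamoyl in place of amino on this saturated ring carbon gives an at least 2.1-fold higher number from compound 1 to compound 3 (0.33 log units; beyond the scatter), so inhibition responds to the group at this place, even though the core of compound 1 already inhibits only weakly. The full size of the step stays unknown because the result for compound 3 is a limit: the limit of > 200000 nM in this assay, at which 1 of the 3 values shown sits.

The compounds shown leave open whether what matters is the amino group leaving or the carbonyl of the carbamoyl group entering, and an aminomethyl group or a carboxylic acid on the same ring carbon could help tell these apart. On these data alone, how a hydroxyl or a methylamino group would read at this place also remains open.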